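Compound 3 and its N-sulfonyl analogue, compound 4

A few compounds are considered here, and "the series" means these few. Any claim that something is new, unique, unknown or untested is made for them only; others in the source may bear on it.

Measured so far in a functional assay on QGY-7703 cells (Homo sapiens) for cytotoxicity, read by MTT assay, with a stated time of 24 h; on this read-out higher numbers stand for weaker inhibition and lower numbers for stronger inhibition
- compound 1 `CN1C/C(=C\c2cccnc2)C(=O)/C(=C/c2ccc(F)cc2Br)C1` gives 2610 nM
- compound 2 `CN1C/C(=C\c2ccncc2)C(=O)/C(=C/c2ccccc2F)C1` gives 4900 nM
- compound 3 `O=C1/C(=C/c2cccnc2)CNC/C1=C\c1ccccc1F` gives 8890 nM

Compound 3 (8890 nM) lies within the usual scatter of compound 2 (4900 nM). Compound 3 has a higher number than compound 1 (2610 nM), and that gap lies beyond the scatter.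

The next compound to be read is compound 4 `O=C1/C(=C/c2cccnc2)CN(S(=O)(=O)c2ccc(F)cc2)C/C1=C\c1ccccc1F`. It differs from compound 3 by one change, with (4-fluorophenyl)sulfonyl in place of hydrogen on an amine nitrogen in a ring.

For the measured compounds named here, no measured pair here differs in one place only, so the data give no direct measure of this change. The enlarged group is a sizeable addition, and a shift in this assay is expected rather than no effect. Compound 1 (2610 nM) shows that numbers well under that of compound 3 occur in this small set, which leans the expectation toward a lower number. The expected change is a moderate step toward stronger inhibition, estimated as a 3.6-fold lower number from compound 3 to compound 4 (0.55 log units; beyond the scatter) with wide uncertainty. For compound 4 the expected value is 2500 nM, with an estimated range from 600 nM to 9000 nM.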

Compound 4, half-maximal inhibitory concentration: 15300 nM
Beside the measured number, compound 4's estimate is 6.1-fold (0.79 log units) below it; the measured number lies above the stated range.
By their numbers in this assay, from the lowest: compounds 1, 2, 3 and 4 (each within the scatter of the next, the first and the last beyond it).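

In this assay, for the compounds shown here, placing (4-fluorophenyl)sulfonyl in place of hydrogen on the amine nitrogen in a ring gives a 1.7-fold higher number from compound 3 to compound 4 (0.24 log units; within the scatter) and this is the only step so far that isolates this position. The step stays within the scatter, so an addition of 10 heavy atoms, including a six-membered aromatic ring, does not separate compound 4 from compound 3 on this read-out, and the ring nitrogen accepts this sulfonyl group without a shift that can be told from repeat variation. No measurement shown here bears on why the step is this small.

A single substituent leaves open how this nitrogen responds to other groups: a methanesulfonyl group would test the sulfonyl link without the aromatic ring, while an acetyl or a benzyl group would test the same position without the sulfonyl link. The methyl group on this nitrogen in compound 1 and compound 2 gives no further reading of the position, since both compounds also differ from compound 3 elsewhere.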